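The source may report more compounds than this note shows. Statements on the series, on what has been measured and on what is new or still open speak of the compounds shown alone.

Measured so far in an ADME assay on Vero cells (Chlorocebus sabaeus) for cytotoxicity, read by neutral red uptake, tested at 197 ug/mL; on this read-out lower numbers stand for a stronger effect and higher numbers for a weaker effect at the one concentration tested:
- compound 1 `O=C1CSC(c2ccc(F)cc2)N1CCN1CCCCC1`: 73%
- compound 2 `COc1ccc(C2SCC(=O)N2CCN2CCCCC2)cc1`: 87%
- compound 3 `O=C1CSC(c2ccccc2[N+](=O)[O-])N1CCN1CCCCC1`: 100%

Compound 1 holds the lowest of the three numbers in this assay, which on this read-out means the strongest effect of the three at the one concentration tested. Going by the values given here, the nearest number is that of compound 2, and the only step measured between close pairs is a number 14 percentage points higher from compound 1 to compound 2 (beyond the scatter), a rise beyond the scatter. Among the compounds with values here, compound 3 sits furthest from compound 1, also beyond the scatter, but no single-point step connects the two.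

Compound 4 `Cc1ccc(C2SCC(=O)N2CCN2CCCCC2)cc1` differs from compound 1 as follows: methyl in place of fluoro on an aromatic carbon. Within the data shown here, the one step that bears on this is the exchange at the same aromatic carbon already seen, a number 14 percentage points higher from compound 1 to compound 2 (beyond the scatter), where another small group took the place of fluoro and the number moved modestly upward. A methyl is a different group from a methoxy, so the same size of move is not assured; a step of modest size upward or none beyond the scatter is the expectation in this assay.

Compound 4 is therefore expected to give about 80%, in a range from 62% to 98%, which would mean an expected step of a number 7 percentage points higher from compound 1 to compound 4 (within the scatter).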

Compound 4, a percentage reported as activity, at one concentration (the size of the read-out at that concentration, not a potency): 85%
Compound 4: middle estimate off by 5 percentage points, on the low side; measured number inside the range.
By their numbers in this assay, from the lowest: compound 1; then compounds 4 and 2 (each within the scatter of the next); then compound 3.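

In this assay the exchange of fluoro for methyl on the aromatic carbon para to a large group gives a number 12 percentage points higher from compound 1 to compound 4 (beyond the scatter) and so marks a second replacement of fluoro at this position that moves the number beyond the scatter, after the methoxy exchange. The change from methoxy to methyl at the same carbon gives a number 2 percentage points lower from compound 2 to compound 4 (within the scatter) and leaves these two groups not told apart on this read-out, so that among the three groups compared at this position only fluoro stands apart from the other two. Nothing available here bears on why fluoro differs from methyl and methoxy at this carbon.

Going by these compounds, whether a chloro or bromo group at the same carbon would read with compound 1 or with compound 2 and compound 4 remains open, as does the number for a plain phenyl with only hydrogen there. Also open, on these data alone, is how a group of another kind at this carbon would read, such as an amine or a carboxylic acid.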